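The source may report more compounds than this note shows. Statements on the series, on what has been measured and on what is new or still open speak of the compounds shown alone.

Two analogues of the shared core have been tested in a functional assay on Hs-578T cells (Homo sapiens) for inhibition, read by sulforhodamine B assay, with a stated time of 48 h; a lower number here means a stronger inhibitor of growth, a higher number a weaker inhibitor of growth. Compound 1, `CCOC(=O)[C@H](CCC(=O)O)NC(=O)c1ccc(CNc2nc3cc(N)cc(N)c3nc2-c2ccccc2)cc1`, returns no number at all: in this assay compound 1 gives < 100000 nM, which is a limit of the assay and not a measured value. The record on that point reads (the limit of < 100000 nM in this assay, at which 1 of the 2 values shown sits). For the measured compounds named here, compound 2, `Nc1cc(N)c2nc(-c3ccccc3)c(NCc3ccc(Cl)c(Cl)c3)nc2c1`, is therefore the single compound with an actual number: in this assay compound 2 gives 46800 nM, and it is the only anchor from which to work.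

Compound 3, `COc1ccc(CNc2nc3cc(N)cc(N)c3nc2-c2ccccc2)cc1`, has not yet been measured in this assay. It differs from compound 2 in one place: 4-methoxyphenyl in place of 3,4-dichlorophenyl on a saturated chain carbon bound to a nitrogen on an aromatic ring. Going by the values given here, no step between two measured compounds covers this change, so both its size and its direction are open. The working expectation is a step no larger than the usual scatter, leaning if anything toward a weaker inhibitor of growth; the expected step is a 1.3-fold higher number from compound 2 to compound 3 (0.11 log units; within the scatter). For compound 3 the estimate in this assay is 60000 nM, with a range from 20000 nM to 150000 nM, and a fair chance that only a limit is returned.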

Compound 3, concentration for total growth inhibition: < 100000 nM
Compound 3 ended at the assay's limit; the forecaster's own chance of this, stated with the estimate: 40%; the middle value does not contradict the limit.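

In this assay, for the compounds shown here, compound 3 gives < 100000 nM, which is a limit of the assay and not a number, so no step from compound 2 to compound 3 can be read. The compounds shown leave open whether 4-methoxyphenyl in place of 3,4-dichlorophenyl changes growth inhibition at all, and in which direction.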